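Thiophenylmethyl amide replaces trifluoromethylphenyl amide: cytotoxicity outlook

The source may report more compounds than this note shows. Statements on the series, on what has been measured and on what is new or still open speak of the compounds shown alone.

Measured compounds:
Compound 1, `COc1cc(-c2cc(C(=O)O)c3ccccc3n2)ccc1OCC(=O)Nc1ccc(C)cc1`, > 300000 nM (a limit)
Compound 2, `COc1cc(-c2cc(C(=O)O)c3ccccc3n2)ccc1OCC(=O)Nc1ccccc1F`, 161000 nM
Compound 3, `COc1cc(-c2cc(C(=O)O)c3ccccc3n2)ccc1OCC(=O)Nc1ccc(C(F)(F)F)cc1`, 150000 nM

The three measured compounds share one core and differ only in the group on the amide-type nitrogen. In an ADME assay on HaCaT cells (Homo sapiens) for inhibition (a higher number here means a weaker inhibitor, a lower number a stronger inhibitor), compound 1 reaches only the limit of the assay, > 300000 nM. Compound 2 gives 161000 nM in this assay. Compound 3 gives 150000 nM, and the step between these two is a 1.1-fold lower number from compound 2 to compound 3 (0.03 log units; within the scatter), so the two numbers cannot be told apart. Compound 3 therefore stands among values that are all alike or at the limit, (the limit of > 300000 nM in this assay, at which 1 of the 3 values shown sits).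

Compound 4, `COc1cc(-c2cc(C(=O)O)c3ccccc3n2)ccc1OCC(=O)NCc1cccs1`, is not yet measured. Its change from compound 3 is (thiophen-2-yl)methyl in place of 4-(trifluoromethyl)phenyl on an amide-type nitrogen. Within the data shown here, the steps that bear on it are all changes of the group on the amide-type nitrogen: an at least 1.8-fold lower number from compound 1 to compound 2 (0.27 log units; that floor lies within the scatter), an at least 2.0-fold lower number from compound 1 to compound 3 (0.30 log units; that floor lies within the scatter) and a 1.1-fold lower number from compound 2 to compound 3 (0.03 log units; within the scatter), none of which reaches beyond the scatter. No step in this set therefore gives reason to expect a change beyond the scatter for compound 4, and the expected step is a 1.1-fold higher number from compound 3 to compound 4 (0.05 log units; within the scatter). Compound 4 is thus estimated at 170000 nM, between 70000 nM and 400000 nM, with a real chance that the assay reports only a limit.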

Compound 4, half-maximal inhibitory concentration: > 300000 nM
Compound 4 gave a limit, no number; the forecaster's own chance of this, stated with the estimate: 30%; middle value at least 1.7-fold (0.24 log units) away from the limit.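

In this assay, among these compounds, (thiophen-2-yl)methyl is the first group on the amide-type nitrogen with a five-membered aromatic ring holding a hetero atom, and it gives an at least 2.0-fold higher number from compound 3 to compound 4 (0.30 log units; that floor lies within the scatter) and an at least 1.8-fold higher number from compound 2 to compound 4 (0.27 log units; that floor lies within the scatter). Compound 4 joins compound 1 at the limit of the assay, which leaves the step between those two unreadable: the limit of > 300000 nM in this assay, at which 2 of the 4 values shown sit. The two groups that give a number, 2-fluorophenyl and 4-(trifluoromethyl)phenyl, both carry fluorine, while 4-methylphenyl and (thiophen-2-yl)methyl reach only the limit, yet no change at this position has so far been shown to go beyond the scatter.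

As far as these compounds go, it remains open whether the thiophene ring or the methyl link sets compound 4 apart from compound 2 and compound 3, a question that a benzyl group or a thiophen-2-yl group without the link on the same nitrogen would address. Also open, from the compounds shown here alone, is how a fluorothiophene ring, a longer chain or a basic amine on this nitrogen would read in this assay.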